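The source may hold more compounds than are shown below. What is called first, only, known or untested is meant among the compounds shown, and "the series" means these compounds.

Compound 3, with the structure `OC[C@H]1OC(n2cnc3c(-c4ccc(F)cc4)ncnc32)[C@H](O)[C@@H]1O`, is the starting point. In a functional assay on CCRF-CEM cells (Homo sapiens) for inhibition (on this read-out lower numbers stand for stronger inhibition and higher numbers for weaker inhibition), compound 3 gives 700 nM. Among the two compounds with a number, compound 3 has the lower value, yet the gap to its nearest neighbour, compound 1 with the structure `OC[C@H]1OC(n2cnc3c(-c4ccc(Cl)cc4)ncnc32)[C@H](O)[C@@H]1O`, is small: compound 1 gives 900 nM, and the step of a 1.3-fold lower number from compound 1 to compound 3 (0.11 log units; within the scatter) lies within the scatter. Compound 2, with the structure `Cn1nccc1-c1ncnc2c1ncn2C1O[C@H](CO)[C@@H](O)[C@H]1O`, has no number at all; in this assay compound 2 is reported as "not active" (no number reported).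

Compound 4, with the structure `OC[C@H]1OC(n2cnc3c(-c4nccs4)ncnc32)[C@H](O)[C@@H]1O`, is not yet measured. It differs from compound 3 in one place: 1,3-thiazol-2-yl in place of 4-fluorophenyl on an aromatic carbon. Among the compounds with values here, the only measured step that touches this part of the molecule is the swap of halogens on the six-membered ring, a 1.3-fold lower number from compound 1 to compound 3 (0.11 log units; within the scatter), which is within the scatter and tells little about exchanging the whole ring for a five-membered one. Compound 2, which also carries a five-membered aromatic ring where compounds 1 and 3 carry a phenyl, gave no measurable activity, so a weaker result is the more likely outcome for compound 4.

For compound 4 the expected step is a 4.3-fold higher number from compound 3 to compound 4 (0.63 log units; beyond the scatter), towards a higher number. The estimate for compound 4 is 3000 nM, with a range from 800 nM to 15000 nM.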

Compound 4, half-maximal inhibitory concentration: 2730 nM
Compound 4: the middle estimate sits 1.1-fold (0.04 log units) above what was measured, within the range that was stated.
By their numbers in this assay, from the lowest: compounds 3 and 1 (each within the scatter of the next); then compound 4.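

In this assay, exchanging the whole ring at this position moves the number beyond the scatter, which the halogen swap did not do: the change is a 3.9-fold higher number from compound 3 to compound 4 (0.59 log units; beyond the scatter), and measured against the chloro partner it is a 3.0-fold higher number from compound 1 to compound 4 (0.48 log units; beyond the scatter). Both steps are modest, so a five-membered aromatic ring with two hetero atoms does not end activity here: compound 4 still gives a number, whereas compound 2, which also carries a five-membered aromatic ring at this carbon, gives "not active" (no number reported). Nothing measured here accounts for the size of these steps or for the contrast between compound 4 and compound 2.

The 1,3-thiazol-2-yl group differs from the halogenated phenyl groups in ring size, in its ring atoms and in lacking a halogen, and these differences change together in the compounds shown, so their separate contributions stay unresolved. Also open, on these data alone, is how this aromatic carbon would respond to a plain phenyl without a halogen, a pyridyl ring, or a non-aromatic group such as an amine.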